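Aryloxy ring contraction in an oxazolidinone amide series

The compounds below may be only part of what the source reports. "The series", "measured", "known", "first", "only" and "open" are said of these compounds alone.

Measured compounds:
compound 1 `O=C1OCCN1C(=O)c1ccc(Oc2cccc(Cl)c2)cc1` — 7740 nM
compound 2 `O=C1OCCN1C(=O)c1ccc(OC2CCCCC2)cc1` — 92 nM

Among the compounds with values here, in an assay on HEK293 cells for inhibition of N-acylethanolamine-hydrolyzing acid amidase (Rattus norvegicus), read by LC-MS, with a stated time of 30 min (on this read-out lower numbers stand for stronger inhibition and higher numbers for weaker inhibition), compound 2 gives 92 nM, the lowest of the two numbers so far; its nearest neighbour is compound 1 at 7740 nM. Within the data shown here, the one measured step, an 84-fold lower number from compound 1 to compound 2 (1.92 log units; beyond the scatter), replaced an aromatic ring on the ether oxygen with a saturated one and was large.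

Compound 3 `O=C1OCCN1C(=O)c1ccc(OC2CCCC2)cc1` is not yet measured. The change from compound 2 is cyclopentyl in place of cyclohexyl on an oxygen on an aromatic ring. Among the measured compounds shown here, no measured step exchanges one saturated ring for another of a different size, so the step from compound 1 to compound 2 bears on this only indirectly: it shows that what sits on the ether oxygen matters, not how much a change of ring size alone moves the number. A small step, likely toward a higher number, is expected, a 1.7-fold higher number from compound 2 to compound 3 (0.24 log units; within the scatter), and possibly within the scatter. Compound 3 is therefore estimated at 160 nM, with a range from 50 nM to 500 nM.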

Compound 3, half-maximal inhibitory concentration: 120 nM
Compound 3: the middle estimate sits 1.3-fold (0.12 log units) above what was measured, within the range that was stated.
By their numbers in this assay, from the lowest: compounds 2 and 3 (each within the scatter of the next); then compound 1.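

In this assay the change from a six-membered to a five-membered saturated ring on the ether oxygen stays within the scatter (a 1.3-fold higher number from compound 2 to compound 3 (0.12 log units; within the scatter)), so cyclohexyl and cyclopentyl cannot be told apart at this position. The large step away from 3-chlorophenyl also appears with the smaller ring (a 65-fold lower number from compound 1 to compound 3 (1.81 log units; beyond the scatter)), so it no longer rests on cyclohexyl alone. No measurement accompanies these numbers that could account for either step.

Open, going by these compounds, is how an open-chain group such as n-butyl, a larger ring such as cycloheptyl, or a saturated ring carrying a hydroxyl or an amine would read at this position. Also open, on these data alone, is how plain phenyl would read, so the share of the chlorine in the large steps cannot be separated from that of the aromatic ring.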